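This account rests on a few compounds, and the source may have more. Where it says the series, first, only, none or still open, it means among the compounds named here.

Measured compounds:
compound 1 `O=c1cc(-c2ccccc2)oc2cc(OCCCCNc3nc4ccccc4s3)cc(O)c12` — 48.5 ug/mL in a functional assay on SK-OV-3 cells (Homo sapiens) for cytotoxicity, read by sulforhodamine B assay, with a stated time of 48 h; on this read-out lower numbers stand for stronger inhibition and higher numbers for weaker inhibition
compound 2 `Cc1ccc2nc(NCCCCOc3cc(O)c4c(=O)cc(-c5ccccc5)oc4c3)sc2c1` — 48.4 ug/mL in this assay

In this assay compound 2 stands at the lowest of the two numbers, with compound 1 its nearest neighbour at a number that is a 1.0-fold lower number from compound 1 to compound 2 (0.00 log units; within the scatter) apart, so the two stand level within the scatter. Among the compounds with values here, the only measured step in this pair is that one, a methyl in place of hydrogen on an aromatic carbon of the fused two-ring system, and it moved the read-out not at all beyond the scatter.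

Compound 3 `O=c1cc(-c2ccccc2)oc2cc(OCCCCNc3nc4ccc(C(F)(F)F)cc4s3)cc(O)c12` is not yet measured. It differs from compound 2 by trifluoromethyl in place of methyl on an aromatic carbon. Within the data shown here, no measured step bears directly on a trifluoromethyl at this position; the one step that touches this carbon, from compound 1 to compound 2, was flat. Nothing in the measured pair gives a reason to expect a shift of a size beyond the scatter, in either direction. Compound 3 is therefore estimated at 48 ug/mL, with a range of 24 ug/mL to 96 ug/mL, which as a step is expected to be a 1.0-fold lower number from compound 2 to compound 3 (0.00 log units; within the scatter).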

Compound 3, half-maximal inhibitory concentration: 37.2 ug/mL
The estimate for compound 3 lay 1.3-fold (0.11 log units) above the measured number; measured number inside the range.
By their numbers in this assay, from the lowest: compounds 3, 2 and 1 (each within the scatter of the next).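

In this assay, within the data shown here, the aromatic carbon that had been seen only with hydrogen and methyl now also carries trifluoromethyl, and this gives a 1.3-fold lower number from compound 2 to compound 3 (0.11 log units; within the scatter) against methyl and a 1.3-fold lower number from compound 1 to compound 3 (0.12 log units; within the scatter) against hydrogen. Going from one heavy atom to four at this place, three of them fluorine, thus leaves all three compounds level within the scatter, so the flat read-out of the first step is not confined to methyl but holds across the three groups shown. Nothing measured on these compounds speaks to why the read-out stays level across them.

From the compounds shown here alone, the linking chain and the rest of the core are the same in all three compounds, so it stays open whether a longer chain, or an amine or a carboxylic acid on this aromatic carbon, would move the number beyond the scatter. Also open is whether the same flat picture holds at the other carbons of this six-membered aromatic ring, and on cell lines other than the one shown here.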